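Chain extension between two aryl oxygens: cytotoxicity notes

The source may report more compounds than this note shows. Statements on the series, on what has been measured and on what is new or still open speak of the compounds shown alone.

Compound 1 `CC(C)NC(=N)c1ccc2oc(-c3cccc(OCCCOc4ccccc4)c3)cc2c1` and compound 2 `CC(C)NC(=N)c1ccc2oc(-c3cccc(OCCCCOc4ccccc4)c3)cc2c1` share one core. In an ADME assay on L6 cells (Rattus norvegicus) for cytotoxicity, read by resazurin assay, with a stated time of 70 h (on this read-out higher numbers stand for weaker inhibition and lower numbers for stronger inhibition), compound 1 gives 26500 nM and compound 2 gives 36500 nM. The change between them, (phenoxymethyl in place of phenoxy on a saturated chain carbon, three bonds along the chain from an oxygen on an aromatic ring), gave a 1.4-fold higher number from compound 1 to compound 2 (0.14 log units; within the scatter). Compound 3 `N=C(N)c1ccc2oc(-c3cccc(OCCCCCOc4ccccc4)c3)cc2c1` carries a different core; the difference between the two cores is not broken down here. In this assay compound 3 gives 3000 nM, the lowest of the three numbers, with the gaps to compound 1 and to compound 2 both beyond the scatter. Compound 4 `N=C(N)c1ccc2oc(-c3cccc(OCCCCCCOc4ccccc4)c3)cc2c1` is not yet measured. It differs from compound 3 by phenoxymethyl in place of phenoxy on a saturated chain carbon, five bonds along the chain from an oxygen on an aromatic ring, the same kind of change as from compound 1 to compound 2, though not at the same place: there the group sat three bonds along the chain from an oxygen on an aromatic ring, here it sits five bonds along. Because the same kind of change earlier gave only a 1.4-fold higher number from compound 1 to compound 2 (0.14 log units; within the scatter), compound 4 is expected to move little, with a 1.2-fold higher number from compound 3 to compound 4 (0.07 log units; within the scatter). The estimate for compound 4 in this assay is 3500 nM, expected to fall between 1500 nM and 8000 nM.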

Compound 4, half-maximal inhibitory concentration: 3100 nM
The estimate for compound 4 lay 1.1-fold (0.05 log units) above the measured number; the range from low to high includes it.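

In this assay, phenoxymethyl in place of phenoxy on a saturated chain carbon, five bonds along the chain from an oxygen on an aromatic ring, gave a 1.0-fold higher number from compound 3 to compound 4 (0.01 log units; within the scatter). Set beside the earlier step, the change reads the same on both cores: the same change on two cores in this assay, a 1.4-fold higher number (0.14 log units; within the scatter) from compound 1 to compound 2 and a 1.0-fold higher number (0.01 log units; within the scatter) from compound 3 to compound 4, 1.3-fold (0.12 log units) apart, within the scatter of two such steps

Among the compounds shown here, this shows that the change left the cytotoxicity number in place on both cores, but with only two steps, each at its own place on the chain, it does not show that the result would hold on a further core or separate the effect of the core from that of the place.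

The compounds shown leave open how much of the gap between the two pairs belongs to the core alone, since no compound of one core carries the same chain as a compound of the other. They also leave open whether a longer chain would read the same on either core, and whether an amine or a carboxylic acid in place of the phenoxy group would move the number.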